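The source may hold more compounds than are shown below. What is called first, only, known or untested is meant among the compounds shown, and "the series" means these compounds.

Series notes on an assay on isolated protein for binding affinity to 5-hydroxytryptamine receptor 6 (Homo sapiens), tested at 10 uM; on this read-out higher numbers stand for more inhibition at the one concentration tested (going by the name of the read-out) and lower numbers for less inhibition:
- compound 1 `CC(C)Cc1cc(CNS(=O)(=O)c2cccc(Cl)c2)nn1-c1ccccc1` gives 40.8%
- compound 2 `CC(C)Cc1cc(CNS(=O)(=O)c2ccc(C(C)(C)C)cc2)nn1-c1ccccc1` gives 51.1%

For the measured compounds named here, compound 2 holds the higher of the two readings in this assay; the only measured step, a number 10.3 percentage points higher from compound 1 to compound 2 (beyond the scatter), separates it from compound 1. That step is also the only one that bears on the next change, since it too alters the group on the sulfonyl sulfur. Compound 3 `CC(C)Cc1cc(CNS(=O)(=O)c2ccc3ccccc3c2)nn1-c1ccccc1` differs from compound 2 by naphthalen-2-yl in place of 4-(tert-butyl)phenyl on a sulfonyl sulfur. Going by the values given here, the one measured exchange at this position moved the reading modestly, beyond the scatter, in a single direction; no second exchange shows whether a further aryl variation keeps that level or returns towards the reading of compound 1. Among the compounds with values here, with only one aryl-for-aryl swap to go by, the reading for compound 3 is expected to stay near that of compound 2, so the step of a number 1.1 percentage points lower from compound 2 to compound 3 (within the scatter) is expected to fall within the scatter. For compound 3 the estimate in this assay is 50%, with a range from 30% to 70%.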

Compound 3, a percentage reported as inhibition, at one concentration (the size of the read-out at that concentration, not a potency): 67.8%
Compound 3: the middle estimate sits 17.8 percentage points below what was measured; measured number inside the range.
By their numbers in this assay, from the lowest: compound 1; then compound 2; then compound 3.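

In this assay, the group on the sulfonyl sulfur now shows a second exchange beyond the scatter: going from 4-(tert-butyl)phenyl to naphthalen-2-yl gives a number 16.7 percentage points higher from compound 2 to compound 3 (beyond the scatter), and going from 3-chlorophenyl to naphthalen-2-yl gives a number 27 percentage points higher from compound 1 to compound 3 (beyond the scatter). The reading therefore changes even though the groups in the first exchange match in heavy atoms, all carbon, and in hydrogen-bond donors, hydrogen-bond acceptors and net charge, the visible difference being one six-membered aromatic ring against two. No experimental finding is available to explain this difference.

Going by these compounds, the three compounds share the rest of their structure and carry only aryl groups on the sulfonyl sulfur, so it remains open whether a pyridine ring, a saturated cyclohexyl ring or a short alkyl chain there would hold the reading of compound 3. Each reading also comes from one concentration, which leaves the potency of compound 3 open, along with whether the order among these three groups would persist if the isobutyl or phenyl group on the shared core were exchanged.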